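Trifluoromethyl in place of methyl on the core of compound 1

The source may report more compounds than this note shows. Statements on the series, on what has been measured and on what is new or still open speak of the compounds shown alone.

Compound 1 `Cc1cc(=O)oc2cc(OCC(=O)c3ccccc3C(F)(F)F)ccc12`: 20400 nM
Compound 2 `Cc1cc(=O)oc2cc(OCC(=O)c3cccc(C(F)(F)F)c3)ccc12`: > 100000 nM
Compound 3 `O=C(COc1ccc2c(C(F)(F)F)cc(=O)oc2c1)c1cc(C(F)(F)F)cc(C(F)(F)F)c1`: "not active" (no number reported)

All three entries come from a functional assay on CWR22R cells (Homo sapiens) for antiproliferative activity, with a stated time of 96 h; a lower number here means a stronger inhibitor, a higher number a weaker inhibitor. Compound 1, at 20400 nM, is the only one of the three with a measured number, so it is the sole numerical reference for the series.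

Compound 2 is recorded at > 100000 nM, which is a limit and not a number. The same point appears in the series summary as the limit of > 100000 nM in this assay, at which 1 of the 3 values shown sits.

Compound 3 is reported as "not active" (no number reported), with no number.

The next compound to be tested is compound 4 `O=C(COc1ccc2c(C(F)(F)F)cc(=O)oc2c1)c1ccccc1C(F)(F)F`. It keeps the side chain of compound 1 and carries trifluoromethyl in place of methyl on an aromatic carbon, opposite the ring oxygen (trifluoromethyl in place of methyl on an aromatic carbon).

Within the data shown here, no measured pair isolates this change, so the expectation is weakly grounded. Among the measured compounds shown here, the only guide is compound 3, at "not active" (no number reported), which also has trifluoromethyl at this place on the core but differs from compound 4 elsewhere as well. A small loss of potency, or none beyond the scatter, is therefore expected in this assay, and a result reported only as a limit would not be surprising.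

The estimated change is a 1.5-fold higher number from compound 1 to compound 4 (0.17 log units; within the scatter).

For compound 4 the expected value is 30000 nM, with an estimated range of 8000 nM to 100000 nM.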

Compound 4, half-maximal inhibitory concentration: "not active" (no number reported)
Nothing numeric was reported for compound 4; no gap can be computed for the estimate.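

Among these compounds, compound 4 is reported as "not active" with no number, so no step from compound 1, at 20400 nM, to compound 4 can be read in this assay. The compounds shown leave open how large an effect trifluoromethyl in place of methyl on the core has: no pair with two numbers isolates this change.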